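The source may hold more compounds than are shown below. What is called first, only, known or untested is meant among the compounds shown, and "the series" means these compounds.

Among the measured compounds shown here, compound 1 `C[C@H]1C[C@@H](c2ccncc2NC(=O)c2nc(-c3c(F)cccc3F)ncc2N)C[C@@H](O)[C@@]1(O)CF` holds the lowest of the two numbers so far recorded in a functional assay on KMS-11 cells (Homo sapiens) for antiproliferative activity, read by a luciferase reporter, with a stated time of 72 h; a higher number here means that more compound is needed for the effect, a lower number that less compound is needed: in this assay compound 1 gives 250 nM. For the measured compounds named here, the only other measured compound, compound 2 `C[C@H]1C[C@@H](c2ccncc2NC(=O)c2nc(-c3ncccc3F)ccc2N)C[C@@H](O)[C@@]1(O)CF`, gives 1740 nM in this assay, a higher number, and the gap between compound 1 and compound 2 lies beyond the usual scatter. Compound 3 `C[C@H]1C[C@@H](c2ccncc2NC(=O)c2nc(-c3c(F)cccc3F)ncc2N)C[C@@H](O)[C@]1(C)O` is yet to be measured in this assay. It differs from compound 1 in one place, (hydrogen in place of fluoro on a saturated chain carbon bound to a saturated ring carbon), so that the fluoromethyl on the saturated ring carbon becomes a methyl. Going by the values given here, no measured pair shows a change of this kind, so the direction of its effect is not known from the data. Compound 3 is expected to give 350 nM in this assay, within a range of 150 nM to 900 nM. The expected step of a 1.4-fold higher number from compound 1 to compound 3 (0.15 log units; within the scatter) is small, and is estimated to lie close to, or only slightly beyond, the scatter.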

Compound 3, half-maximal effective concentration in the KMS-11 assay: 930 nM
Estimate against measurement, compound 3: 2.7-fold (0.42 log units) below, and the stated range ends below it.
By their numbers in the KMS-11 assay, from the lowest: compound 1; then compounds 3 and 2 (each within the scatter of the next).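

On a saturated chain carbon bound to a saturated ring carbon, hydrogen in place of fluoro is not a silent change in the KMS-11 assay: the result is a 3.7-fold higher number from compound 1 to compound 3 (0.57 log units; beyond the scatter), so the fluoromethyl of compound 1 counts for this read-out. In a physicochemical assay for lipophilicity, at pH 7.4 (a higher number here means a more lipophilic compound, a lower number a more polar compound), compound 1 gives 1.4 and compound 3 gives 2.8. In this single pair, then, more compound is needed for the antiproliferative effect as the compound becomes more lipophilic: the measured distribution coefficient of compound 1, 1.4, and of compound 3, 2.8, a number 1.40 log units higher (beyond the scatter)

A single pair cannot show whether the numbers in the KMS-11 assay and in the physicochemical assay move together beyond compound 1 and compound 3. It also leaves open how a hydroxymethyl, a difluoromethyl or a longer chain would behave at this place, and whether the same step would appear on the core of compound 2.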